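Solubility of a nitroimidazole oxazine series: morpholine to piperidine

The compounds below may be only part of what the source reports. "The series", "measured", "known", "first", "only" and "open" are said of these compounds alone.

The measured compounds:
compound 1 `C[C@]1(COc2ccc(S(=O)(=O)N3CCOCC3)cc2)Cn2cc([N+](=O)[O-])nc2O1`: 20 ug/mL
compound 2 `CCOc1ccc(NC(=O)Nc2ccc(OC[C@@]3(C)Cn4cc([N+](=O)[O-])nc4O3)cc2)cc1`: 6.66 ug/mL
compound 3 `COc1ccc(S(=O)(=O)N2CCN(c3ccc(OC[C@@]4(C)Cn5cc([N+](=O)[O-])nc5O4)cc3)CC2)cc1`: < 1 ug/mL

In a physicochemical assay for solubility, read by HPLC, with a stated time of 4 h, at pH 7 (on this read-out lower numbers stand for lower solubility and higher numbers for higher solubility), compound 1 gives 20 ug/mL, the highest of the two numbers shown; the nearest is compound 2, at 6.66 ug/mL, a gap beyond the scatter. For compound 3 the assay reports only a limit, < 1 ug/mL, which is one of the limit of < 1 ug/mL in this assay, at which 1 of the 3 values shown sits. Compound 4 `C[C@]1(COc2ccc(S(=O)(=O)N3CCCCC3)cc2)Cn2cc([N+](=O)[O-])nc2O1` is not yet measured in this assay. Compared with compound 1, the change is piperidin-1-yl in place of morpholin-4-yl on a sulfonyl sulfur. Going by the values given here, no measured pair shows this step. Compound 4 is expected to come out lower in this assay, with a step of a 2.5-fold lower number from compound 1 to compound 4 (0.40 log units; beyond the scatter) that is estimated to lie beyond the scatter. Compound 4 is estimated at 8 ug/mL, within 3 ug/mL to 25 ug/mL.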

Compound 4, solubility: 13.3 ug/mL
Beside the measured number, compound 4's estimate is 1.7-fold (0.22 log units) below it, within the range that was stated.
By their numbers in this assay, from the lowest: compounds 2, 4 and 1 (each within the scatter of the next, the first and the last beyond it). At a limit, below all of these: compound 3.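

In this assay, the change on the sulfonyl sulfur gives a 1.5-fold lower number from compound 1 to compound 4 (0.18 log units; within the scatter) and so lies within the scatter. In this one pair, piperidin-1-yl in place of morpholin-4-yl, with the hydrogen-bond acceptor of morpholin-4-yl gone, leaves no readable difference at this position. Nothing shown here bears on why that is so.

As far as these compounds go, whether an open-chain amine such as dimethylamino, or a piperidin-1-yl ring carrying a carboxylic acid, would give a step beyond the scatter on this sulfonyl sulfur stays open. So does whether this step would read the same on another core.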